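Plasma Stability: Adding a Second Carbonate Ester to Compound 1

The compounds below may be only part of what the source reports. "The series", "measured", "known", "first", "only" and "open" are said of these compounds alone.

Measured compounds:
Compound 1 `Cc1oc(=O)oc1COC(=O)c1cccc(NC(=O)[C@@H]2C[C@H](SC3=C(C(=O)O)N4C(=O)[C@H]([C@@H](C)O)[C@H]4[C@H]3C)CN2)c1` in an ADME assay on a cell-free system (plasma, Homo sapiens) for metabolic stability, read by LC-MS, with a stated time of 60 min, at 37 degrees C, tested at 50 uM (on this read-out higher numbers stand for a more stable compound and lower numbers for a less stable compound), gives 12%.
Compound 2 `CCCOC(=O)C1=C(S[C@@H]2CN[C@H](C(=O)Nc3cccc(C(=O)OCCC)c3)C2)[C@H](C)[C@@H]2[C@@H]([C@@H](C)O)C(=O)N12` in this assay gives 7%.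
Compound 3 `CC(C)OC(=O)c1cccc(NC(=O)[C@@H]2C[C@H](SC3=C(C(=O)O)N4C(=O)[C@H]([C@@H](C)O)[C@H]4[C@H]3C)CN2)c1` in this assay is recorded as "not determined" (no result reported), with no result reported.

Among the two compounds with a number, compound 1 stands at the higher value, and compound 2 sits at a value only a few points away, within the scatter of the method, so no order between them can be claimed. Compound 3 adds nothing to the comparison, since no number exists for it.

Compound 4 `Cc1oc(=O)oc1COC(=O)C1=C(S[C@@H]2CN[C@H](C(=O)Nc3cccc(C(=O)OCc4oc(=O)oc4C)c3)C2)[C@H](C)[C@@H]2[C@@H]([C@@H](C)O)C(=O)N12` differs from compound 1 by one change: a group of 8 heavy atoms (5 carbon, 3 oxygen; one five-membered aromatic ring with 2 hetero atoms) in place of a hydrogen atom, on an oxygen next to a carbonyl group. Among the measured compounds shown here, no step between measured compounds tracks this change, so the expectation rests on the two low values alone. Both measured compounds show little material left after an hour, and compound 4 is estimated to show a similarly low level, with a step of a number 6 percentage points lower from compound 1 to compound 4 (within the scatter) that is expected to stay within the scatter. Compound 4 is expected to give 6%, between 1% and 15%.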

Compound 4, percent of the compound remaining: 1%
For compound 4 the middle estimate is 5 percentage points above the measured one, and the stated range covers the measured number.
By their numbers in this assay, from the lowest: compounds 4, 2 and 1 (each within the scatter of the next, the first and the last beyond it).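

Among the compounds shown here, the earlier compounds offered no step between measured structures, so this is the first direct reading of a change at this position. In this assay, putting the 8-heavy-atom group with its five-membered aromatic ring in place of the hydrogen atom, on an oxygen next to a carbonyl group, gives a drop of a number 11 percentage points lower from compound 1 to compound 4 (beyond the scatter), so filling this position does not preserve more of the compound after the incubation, and compound 4 gives 1%. Nothing available explains why the value falls at this position.

The compounds shown leave open whether a smaller or differently shaped group on this oxygen, such as a methyl or a tert-butyl group, would give a different reading in this assay. They also leave open how an amide at the same carbonyl group or a longer chain on this oxygen would read.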